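Working notes: an aryl swap on compound 2

The source may hold more compounds than are shown below. What is called first, only, known or untested is meant among the compounds shown, and "the series" means these compounds.

Measured in an in vivo ADME assay on the whole organism for metabolic stability, with Rattus norvegicus as the target; on this read-out higher numbers stand for a longer-lived compound and lower numbers for a shorter-lived compound:
- compound 1 `CC(C)(C)N1CCC(c2cc(-c3ccc(F)cc3Cl)c3ccc(=O)n(-c4c(Cl)cccc4Cl)c3c2)CC1`: 3.5 h
- compound 2 `CC(C)(C)N1CCC(c2cc3c(ccc(=O)n3-c3c(Cl)cccc3Cl)c(-c3ccc(F)cc3F)n2)CC1`: 9.05 h

Compound 2 holds the higher of the two numbers at 9.05 h, and compound 1 at 3.5 h lies lower, a gap beyond the scatter. These two compounds differ in more than one place, so the gap cannot be assigned to any single change.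

The next compound is compound 3 `CC(C)(C)N1CCC(c2cc3c(ccc(=O)n3-c3c(Cl)cccc3Cl)c(-c3ccccc3Cl)n2)CC1`, which departs from compound 2 in one place: 2-chlorophenyl in place of 2,4-difluorophenyl on an aromatic carbon. It carries 2-chlorophenyl in place of 2,4-difluorophenyl on an aromatic carbon, next to the ring nitrogen and ortho to a fused ring. Among the compounds with values here, no measured pair isolates a change of this kind, so the expectation is loose. Compound 1, at 3.5 h, also carries a chlorine on the corresponding phenyl ring, and this single number gives only a weak lean downward. In this assay a modest drop is therefore expected, probably not beyond the scatter. The expected change is a 1.5-fold lower number from compound 2 to compound 3 (0.18 log units; within the scatter). Compound 3 is estimated at 6 h, with an expected range of 3 h to 12 h.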

Compound 3, half-life: 5.1 h
Estimate against measurement, compound 3: 1.2-fold (0.07 log units) above; the measured number falls inside the stated range.
By their numbers in this assay, from the lowest: compounds 1, 3 and 2 (each within the scatter of the next, the first and the last beyond it).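

In this assay, within the data shown here, the exchange of 2,4-difluorophenyl for 2-chlorophenyl on the aromatic carbon next to the ring nitrogen gives a 1.8-fold lower number from compound 2 to compound 3 (0.25 log units; within the scatter) and is the first comparison that isolates a single change. The two compounds therefore cannot be told apart on this read-out, so at this position on this core the half-life does not depend on keeping 2,4-difluorophenyl rather than 2-chlorophenyl. The comparison says nothing about the gap between compound 1 and compound 2, which still involves more than one difference.

Among these compounds, the single pair also changes the halogen and the number of substituents on the phenyl ring together, so these two differences cannot be separated here. How far this tolerance extends remains open, since an unsubstituted phenyl, a methoxyphenyl or a pyridyl on the same carbon lies outside the compounds shown, and the tert-butyl group on the piperidine is constant throughout them. No supporting data on the origin of this result are available here.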